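The source may report more compounds than this note shows. Statements on the series, on what has been measured and on what is new or still open speak of the compounds shown alone.

Measured compounds in a physicochemical assay for lipophilicity, read by HPLC, at pH 7.4; a higher number here means a more lipophilic compound, a lower number a more polar compound:
- compound 1, `CCOC(=O)C1=C(C)N/C(=C/c2cc(C)n(-c3ccc(Br)cc3)c2C)C1=O`, gives 3.4
- compound 2, `CCOC(=O)C1=C(C)N/C(=C/c2cc(C)n(-c3cccc(OC)c3)c2C)C1=O`, gives 2.9
- compound 3, `CCOC(=O)C1=C(C)N/C(=C/c2cc(C)n(-c3ccncc3)c2C)C1=O`, gives 3.2

Compound 1 holds the highest of the three numbers in this assay. Its nearest neighbour is compound 3, with a number 0.20 log units lower from compound 1 to compound 3 (within the scatter); the furthest is compound 2, with a number 0.50 log units lower from compound 1 to compound 2 (beyond the scatter). Between the other two, a number 0.30 log units higher from compound 2 to compound 3 (within the scatter).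

Compound 4, `CCOC(=O)C1=C(C)N/C(=C/c2cc(C)n(-c3cccnc3)c2C)C1=O`, is not yet measured. It differs from compound 1 in one place: pyridin-3-yl in place of 4-bromophenyl on an aromatic nitrogen.

Among the measured compounds shown here, the step that bears most directly on this change is the one from compound 1 to compound 3, where the same aryl group on the aromatic nitrogen was exchanged for pyridin-4-yl and the result was a number 0.20 log units lower from compound 1 to compound 3 (within the scatter). The step to compound 2 shows a larger drop, a number 0.50 log units lower from compound 1 to compound 2 (beyond the scatter), but with a different entering group. On the evidence of compound 3, a pyridin-3-yl in the same position is expected to give at most a small drop in this assay, likely within the scatter, so a number 0.20 log units lower from compound 1 to compound 4 (within the scatter) is expected. Compound 4 is therefore estimated at 3.2, with a range from 2.8 to 3.6.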

Compound 4, distribution coefficient: 2.1
Estimate against measurement, compound 4: 1.10 log units above; the measured number lies below the stated range.
By their numbers in this assay, from the lowest: compound 4; then compounds 2, 3 and 1 (each within the scatter of the next, the first and the last beyond it).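

In this assay, the two pyridine isomers are not interchangeable on the aromatic nitrogen: pyridin-3-yl in place of pyridin-4-yl gives a number 1.10 log units lower from compound 3 to compound 4 (beyond the scatter), so compound 3 did not predict the behaviour of this isomer. The same group also separates clearly from the two substituted phenyl groups, with a number 1.30 log units lower from compound 1 to compound 4 (beyond the scatter) and a number 0.80 log units lower from compound 2 to compound 4 (beyond the scatter), which leaves compound 4 alone at the low end of this set, beyond the scatter of the other three. Nothing available here accounts for the gap between the two isomers.

Going by these compounds, whether pyridin-2-yl on the same nitrogen would sit with compound 3 or with compound 4 remains open. Also open, on these data alone, is whether the low number of compound 4 would persist with an amine or a methyl group added to the pyridin-3-yl ring.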